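A few compounds are considered here, and "the series" means these few. Any claim that something is new, unique, unknown or untested is made for them only; others in the source may bear on it.

Measured so far in a functional assay on HepG2 cells (Homo sapiens) for cytotoxicity, read by MTT assay, with a stated time of 48 h; on this read-out higher numbers stand for weaker inhibition and lower numbers for stronger inhibition:
- compound 1 `COc1cc(-c2nnc3n2NC(c2ccco2)C(C(=O)C2CC2)S3)cc(OC)c1OC`: > 100000 nM, a limit of the assay
- compound 2 `COc1cc(C(=O)C2Sc3nnc(-c4cc(OC)c(OC)c(OC)c4)n3NC2c2cccs2)cc(OC)c1OC`: > 100000 nM, also a limit
- compound 3 `COc1ccc(C(=O)C2Sc3nnc(-c4cc(OC)c(OC)c(OC)c4)n3NC2c2cccs2)cc1`: 68000 nM

Compound 1 therefore stands only at a limit, and the limit of > 100000 nM in this assay, at which 2 of the 3 values shown sit, shows that the same holds for most of the set. Compound 4 `COc1cccc(C(=O)C2Sc3nnc(-c4cc(OC)c(OC)c(OC)c4)n3NC2c2ccco2)c1` differs from compound 1 in one place: 3-methoxyphenyl in place of cyclopropyl on a carbonyl carbon. For the measured compounds named here, no measured step covers this exact change. The closest is an at least 1.4-fold lower number from compound 2 to compound 3 (0.16 log units; that floor lies within the scatter), where a methoxyphenyl replaced another group on the same carbonyl carbon and the number moved at most a little. For compound 4 the step of an at least 1.2-fold lower number from compound 1 to compound 4 (0.09 log units; that floor lies within the scatter) is expected to be similarly small, if any. Compound 4 is estimated at 80000 nM, within 30000 nM to 200000 nM.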

Compound 4, half-maximal inhibitory concentration: > 100000 nM
Compound 4 was reported as a limit (the forecaster's own chance of this, stated with the estimate: 55%); middle value at least 1.2-fold (0.09 log units) from the limit.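

Compound 1 and compound 4 both stand only at a limit, so no step between them can be read: the limit of > 100000 nM in this assay, at which 3 of the 4 values shown sit.

The compounds shown leave open whether 3-methoxyphenyl in place of cyclopropyl on a carbonyl carbon changes the number at all.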